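This account rests on a few compounds, and the source may have more. Where it says the series, first, only, none or still open, it means among the compounds named here.

Of the compounds shown here, three built on one shared core have been measured in a functional assay on HT-29 cells (Homo sapiens) for inhibition, read by MTT assay, with a stated time of 48 h; on this read-out higher numbers stand for weaker inhibition and lower numbers for stronger inhibition. Compound 1 `COc1ccc(-n2c(S)nnc2-c2cc(OC)c(OC)c(OC)c2)cc1` gives only a limit there, > 60000 nM, rather than a number. Compound 2 `COc1ccc(-n2c(SCc3ccc(C)cc3)nnc2-c2cc(OC)c(OC)c(OC)c2)cc1` likewise returns only the limit > 60000 nM. Compound 3 `COc1cc(-c2nnc(S)n2-c2ccc(N(C)C)cc2)cc(OC)c1OC` also rests at the limit > 60000 nM. Because all three sit at the limit of > 60000 nM in this assay, at which 3 of the 3 values shown sit, the step that the two limits leave unreadable from compound 1 to compound 2 and the step that the two limits leave unreadable from compound 1 to compound 3 are both unreadable. Compound 4 `CCOC(=O)CSc1nnc(-c2cc(OC)c(OC)c(OC)c2)n1-c1ccc(N(C)C)cc1` differs from compound 3 by (ethoxycarbonyl)methyl in place of hydrogen on a sulfur. For the measured compounds named here, the one measured step that alters the same sulfur, a step that the two limits leave unreadable from compound 1 to compound 2, could not be sized, so nothing measured tells whether a group on that sulfur moves the read-out in this assay at all. With the three known values all resting at a limit, compound 4 is expected to stay near that limit as well, estimated at 60000 nM with a range from 10000 nM to 100000 nM. The expected step of a number no higher from compound 3 to compound 4 (the limit leaves the size open) is therefore reckoned as none beyond the scatter.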

Compound 4, half-maximal inhibitory concentration: 28800 nM
For compound 4 the middle estimate is 2.1-fold (0.32 log units) above the measured one, within the range that was stated.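

In this assay, the sulfur whose other neighbour is an aromatic carbon now gives a readable result: (ethoxycarbonyl)methyl in place of hydrogen there gives an at least 2.0-fold lower number from compound 3 to compound 4 (0.31 log units; beyond the scatter). For the compounds shown here, the earlier steps cannot be read, which makes this the first sign that a group on this sulfur can move the read-out at all, and the full size of the step stays open with compound 3 resting at a limit. Compound 4 is the only compound shown with a number rather than a limit: the limit of > 60000 nM in this assay, at which 3 of the 4 values shown sit.

The compounds shown leave open whether the ethoxycarbonyl part matters or any chain on the sulfur would do, a question that a carboxylic acid, an amide or a plain propyl chain there could address. Also open, from the compounds shown here alone, is whether (ethoxycarbonyl)methyl on the sulfur of compound 1, with its methoxy group, would give a step of the same kind.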